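Swapping methoxy for chloro on two azido-nucleoside cores

The source may report more compounds than this note shows. Statements on the series, on what has been measured and on what is new or still open speak of the compounds shown alone.

This study compares four nucleoside analogues in an ADME assay on Vero cells (Chlorocebus sabaeus) for cytotoxicity, with a stated time of 5 days; a lower number here means a stronger inhibitor, a higher number a weaker inhibitor. Compound 1 has the structure `COc1nc(NC2CC2)c2ncn([C@H]3C[C@H](N=[N+]=[N-])[C@@H](CO)O3)c2n1`. In this assay compound 1 gives > 100000 nM, which is a limit of the assay and not a number. Compound 2, `[N-]=[N+]=N[C@H]1C[C@H](n2cnc3c(NC4CC4)nc(Cl)nc32)O[C@@H]1CO`, differs from compound 1 by chloro in place of methoxy on an aromatic carbon. In this assay compound 2 gives > 100000 nM, again a limit. The step that the two limits leave unreadable from compound 1 to compound 2 therefore cannot be read, as the two limits hide its size; all that can be said is that (the limit of > 100000 nM in this assay, at which 3 of the 3 values shown sit).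

Compound 3, `COc1nc(F)nc2c1ncn2[C@H]1C[C@H](N=[N+]=[N-])[C@@H](CO)O1`, carries a different core; the difference between the two cores is not broken down here. In this assay compound 3 gives > 100000 nM, which is a limit. Compound 4, `[N-]=[N+]=N[C@H]1C[C@H](n2cnc3c(Cl)nc(F)nc32)O[C@@H]1CO`, has not yet been measured. It differs from compound 3 by chloro in place of methoxy on an aromatic carbon. Among the measured compounds shown here, this is the same kind of change as the one from compound 1 to compound 2, but the surroundings differ: in compound 2 the chloro sits between two ring nitrogen atoms, meta to a cyclopropylamino group, whereas in compound 4 it sits next to the ring nitrogen, opposite the ring nitrogen, and meta to a fluoro group.

Because (the limit of > 100000 nM in this assay, at which 3 of the 3 values shown sit), the step from compound 3 to compound 4 is expected to be small, around a step that the limit leaves unreadable from compound 3 to compound 4. For compound 4 the expected value is 150000 nM, within a range from 60000 nM to 400000 nM.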

Compound 4, half-maximal inhibitory concentration: 21800 nM
Compound 4: middle estimate off by 6.9-fold (0.84 log units), on the high side; the measured number lies below the stated range.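

In this assay, chloro in place of methoxy gives an at least 4.5-fold lower number from compound 3 to compound 4 (0.66 log units; beyond the scatter), so on the core of compound 3 the change has a real effect, and its true size may be larger than this minimum. The same change on the core of compound 1 cannot be read, because the results for compound 1 and compound 2 are both limits of the assay and not numbers: the limit of > 100000 nM in this assay, at which 3 of the 4 values shown sit. The result therefore shows the change at work on one core only; it shows neither that the change carries over to the core of compound 1, which has a cyclopropylamino group where the core of compound 3 has a fluoro group, nor that it fails to.

The compounds shown leave open whether the lower number on the core of compound 3 follows from the arrival of the chloro or from the departure of the methoxy, a question that a bromo group, a methyl group or a longer ethoxy chain at the same place could help to settle. They also leave open how the change would behave on a core carrying a plain amine in place of the cyclopropylamino or fluoro group.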